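Replacing the amine substituent on the shared core

The source may report more compounds than this note shows. Statements on the series, on what has been measured and on what is new or still open speak of the compounds shown alone.

Measured compounds in a functional assay on CHO cells for activation of 5-hydroxytryptamine receptor 1D (Homo sapiens), read by GTPgammaS binding; on this read-out lower numbers stand for smaller maximal responses and higher numbers for larger maximal responses:
compound 1, `OCCC(NC1CCN(CCCc2c[nH]c3ccc(-n4cnnc4)cc23)CC1)c1ccccc1`, 100%
compound 2, `COC[C@H](NC1CCN(CCCc2c[nH]c3ccc(Cn4cncn4)cc23)CC1)c1ccc(F)cc1`, 89%
compound 3, `CC(=O)Nc1ccc([C@H](C)NCC2CCN(CCCc3c[nH]c4ccc(-n5cnnc5)cc34)CC2)cc1`, 99%

Compound 1 gives the highest of the three numbers in this assay. Compound 3 sits within the usual scatter of compound 1, so the two cannot be told apart. Compound 2 lies lower than compound 1 by an amount beyond the scatter. No two of these three compounds differ in only one place, so none of the gaps between them can be tied to a single structural change.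

Compound 4, `CN(Cc1ccsc1)C1CCN(CCCc2c[nH]c3ccc(-n4cnnc4)cc23)CC1`, has not yet been measured. It differs from compound 1 in one place: methyl((thiophen-3-yl)methyl)amino in place of (3-hydroxy-1-phenylpropyl)amino on a saturated ring carbon. The group that leaves carries hydrogen-bond donors; the group that enters carries none, and it is smaller.

For the measured compounds named here, no measured step is available to guide the expectation, so it rests on the structural change alone and on the fact that all three measured compounds reach a high maximal response. A modest decrease is the expected step, a number 15 percentage points lower from compound 1 to compound 4 (beyond the scatter), of a size that may just exceed the scatter. Compound 4 is therefore estimated at 85%, with a likely range from 60% to 105%.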

Compound 4, largest response reached (reported as efficacy), in percent of the reference or control that the assay uses: 93%
The estimate for compound 4 lay 8 percentage points below the measured number; low and high end bracket the measured number.
By their numbers in this assay, from the lowest: compounds 2, 4, 3 and 1 (each within the scatter of the next, the first and the last beyond it).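

In this assay, for the compounds shown here, this is the first step that can be read at this place on the saturated ring carbon: methyl((thiophen-3-yl)methyl)amino in place of (3-hydroxy-1-phenylpropyl)amino gives a number 7 percentage points lower from compound 1 to compound 4 (within the scatter) and so no change that can be told from the scatter. The exchange is a large one, since the group that leaves carries hydrogen-bond donors and a six-membered aromatic ring of carbon only, while the group that enters has no donors, fewer heavy atoms and a five-membered aromatic ring with a hetero atom, so for this pair the high maximal response does not require those donors or that ring. No supporting measurement is available to explain why the response holds.

The donors and the ring changed together in this single step, so their separate contributions cannot be read, and a group such as (1-phenylpropyl)amino, which would keep the phenyl ring without the hydroxyl, would pull them apart. Going by these compounds, how far this tolerance extends at this place also stays open, for example to a plain dimethylamino group or to a group bearing a carboxylic acid.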